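The source may report more compounds than this note shows. Statements on the series, on what has been measured and on what is new or still open speak of the compounds shown alone.

In a functional assay on HCT-116 cells (Homo sapiens) for inhibition, read by MTT assay, with a stated time of 48 h (a lower number here means a stronger inhibitor, a higher number a weaker inhibitor), compound 1 (`COc1ccc(CNc2cc(OC)c(OC)c(OC)c2)cc1Br`) gives 48100 nM and compound 2 (`COC(=O)c1cc(CNc2cc(OC)c(OC)c(OC)c2)ccc1OC`) gives 38100 nM. Both carry a hydrogen on the nitrogen of the shared core. Compound 3 (`C/C=C/C(=O)N(Cc1ccc(OC)c(C)c1)c1cc(OC)c(OC)c(OC)c1`) carries an acyl group there and gives 23500 nM. Among the measured compounds shown here, that number is lower than the one for compound 1 by more than the usual scatter, but it cannot be told apart from the one for compound 2.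

Compound 4 (`COc1ccc(CNc2cc(OC)c(OC)c(OC)c2)cc1C`) differs from compound 3 by hydrogen in place of (prop-1-en-1-yl)carbonyl on a nitrogen on an aromatic ring. For the measured compounds named here, no measured step makes this exact change. The closest evidence is a 1.3-fold lower number from compound 1 to compound 2 (0.10 log units; within the scatter), which swaps one ring group for another among compounds with that hydrogen and stays small. Compound 4 also has that hydrogen, so its number is expected to lie near those of compound 1 and compound 2. The expected change is a 1.8-fold higher number from compound 3 to compound 4 (0.25 log units; within the scatter), an estimated rise towards a higher number that probably stays within the scatter. For compound 4 the estimated value is 42000 nM, with an expected range of 20000 nM to 85000 nM.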

Compound 4, half-maximal inhibitory concentration: 60900 nM
Compound 4: middle estimate off by 1.5-fold (0.16 log units), on the low side, and the stated range covers the measured number.
By their numbers in this assay, from the lowest: compounds 3, 2, 1 and 4 (each within the scatter of the next, the first and the last beyond it).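

In this assay, among the compounds shown here, putting hydrogen in place of (prop-1-en-1-yl)carbonyl on the nitrogen gives a 2.6-fold higher number from compound 3 to compound 4 (0.41 log units; beyond the scatter), the first single change at this nitrogen and one that goes beyond the scatter, so here the acyl group goes with the lower number. With hydrogen on that nitrogen, the ring groups cannot be told apart: methyl in place of methoxycarbonyl gives a 1.6-fold higher number from compound 2 to compound 4 (0.20 log units; within the scatter), and methyl in place of bromo gives a 1.3-fold higher number from compound 1 to compound 4 (0.10 log units; within the scatter). Nothing available explains why the acyl group makes this difference.

From the compounds shown here alone, this rests on one acyl group on one compound, so the same step on compound 1 or compound 2 remains unknown. Also open, going by these compounds, is whether a simple acetyl group or a saturated butanoyl chain on that nitrogen would match the step seen here.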